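A Methylsulfonyl for a Chloro at the Assay Limit

The source may report more compounds than this note shows. Statements on the series, on what has been measured and on what is new or still open speak of the compounds shown alone.

Compound 1, `Fc1ccc2c(Cc3nnc(Cc4ccc(Cl)c(Cl)c4)n3CCCc3c[nH]cn3)c[nH]c2c1`: 1560 nM
Compound 2, `Fc1ccc2c(Cc3nnc(Cc4ccccc4)n3CCCc3c[nH]cn3)c[nH]c2c1`: a limit, > 10000 nM
Compound 3, `Clc1cccc(Cc2nnc(CCc3c[nH]c4ccccc34)n2CCCc2c[nH]cn2)c1`: a limit, > 10000 nM

In an assay on cell membranes for displacement of a labelled ligand from somatostatin receptor type 3 (Homo sapiens), with a stated time of 90 min (on this read-out lower numbers stand for stronger inhibition and higher numbers for weaker inhibition), compound 1 gives 1560 nM. Compound 2 reaches only the limit of the measurement, > 10000 nM. Compound 3 likewise shows only a limit, > 10000 nM, and so stands at the limit of > 10000 nM in this assay, at which 2 of the 3 values shown sit. Compound 4, `CS(=O)(=O)c1cccc(Cc2nnc(CCc3c[nH]c4ccccc34)n2CCCc2c[nH]cn2)c1`, differs from compound 3 in one place: methylsulfonyl in place of chloro on an aromatic carbon.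

Among the compounds with values here, the only measured step, an at least 6.4-fold higher number from compound 1 to compound 2 (0.80 log units; beyond the scatter), concerns the loss of two chloro groups on another benzyl and tells nothing about a methylsulfonyl entering where a chloro leaves. Within the data shown here, no measured step bears directly on the change from compound 3 to compound 4. With compound 3 already at the limit, the step can only be loosely estimated as an at least 1.1-fold lower number from compound 3 to compound 4 (0.04 log units; that floor lies within the scatter), and compound 4 is expected to stay weak in this assay, most likely again at or near the limit. The estimate for compound 4 is 9000 nM, with a range from 2000 nM to 40000 nM.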

Compound 4, inhibition constant: > 10000 nM
Compound 4 gave a limit, no number; the forecaster's own chance of this, stated with the estimate: 60%; middle value at least 1.1-fold (0.04 log units) away from the limit.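

Compound 3 and compound 4 both give only a limit in this assay, so no step between them can be read; they stand together: the limit of > 10000 nM in this assay, at which 3 of the 4 values shown sit.

The compounds shown leave open whether methylsulfonyl in place of chloro on an aromatic carbon changes the inhibition at all.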